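Notes on the bromo to chloro change at compound 2

The compounds below may be only part of what the source reports. "The series", "measured", "known", "first", "only" and "open" are said of these compounds alone.

For the measured compounds named here, compound 2 `CN(C)CN1C(=O)C(=O)c2c(Br)cccc21` gives 93700 nM in a functional assay on MDA-MB-231 cells (Homo sapiens) for cytotoxicity, read by sulforhodamine B assay, with a stated time of 48 h (a higher number here means a weaker inhibitor of growth, a lower number a stronger inhibitor of growth), the highest of the three numbers known; the nearest is compound 1 `O=C1C(=O)N(CN(c2ccccc2)c2ccccc2)c2cccc(Cl)c21` with 31400 nM, and compound 3 `CCN(CC)CN1C(=O)C(=O)c2c(Br)cccc21` gives 20200 nM. Going by the values given here, the only measured single-place step, a 4.6-fold lower number from compound 2 to compound 3 (0.67 log units; beyond the scatter), alters the amine and says nothing about the halogen. Compound 4 `CN(C)CN1C(=O)C(=O)c2c(Cl)cccc21` differs from compound 2 only by chloro in place of bromo on an aromatic carbon. Compound 1 also carries chloro, but it differs from compound 2 in two places, so its value bears only loosely here. Among the compounds with values here, no measured step covers this change, so no movement beyond the scatter is expected for compound 4 in this assay, as a 1.1-fold lower number from compound 2 to compound 4 (0.04 log units; within the scatter). Compound 4 is estimated at 85000 nM, with a range of 35000 nM to 200000 nM.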

Compound 4, concentration for 50% growth inhibition: 138000 nM
For compound 4 the middle estimate is 1.6-fold (0.21 log units) below the measured one; measured number inside the range.
By their numbers in this assay, from the lowest: compounds 3 and 1 (each within the scatter of the next); then compounds 2 and 4 (each within the scatter of the next).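

For the compounds shown here, the first measured reading of chloro in place of bromo on this aromatic carbon in this assay is a 1.5-fold higher number from compound 2 to compound 4 (0.17 log units; within the scatter) and so separates neither halogen from the other. This holds with the dimethylamino side chain of compound 2 and compound 4, whereas the earlier step showed movement only at the amine. Nothing measured bears on why the two halogens read alike.

Still open, going by these compounds, is whether fluoro, methoxy or plain hydrogen on this carbon would also stay within the scatter. Also open, on these data alone, is whether chloro in place of bromo reads the same with the diethylamino side chain of compound 3.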